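Carboxy group of compound 2 replaced by a small uncharged group

This account rests on a few compounds, and the source may have more. Where it says the series, first, only, none or still open, it means among the compounds named here.

Measured so far:
- compound 1, `CCOC(=O)c1ccc(-c2nn(Cc3ccccc3OC)c3ccccc23)cc1`: in a functional assay on cells (Platelet, Homo sapiens) for inhibition (a higher number here means a weaker inhibitor, a lower number a stronger inhibitor), compound 1 gives > 10000 nM, a limit.
- compound 2, `O=C(O)c1ccc(-c2nn(Cc3ccccc3)c3ccccc23)cc1`: in this assay compound 2 gives > 10000 nM, also a limit.

Compound 2 thus stands at the limit of the assay, not at a number, and both values shown share it (the limit of > 10000 nM in this assay, at which 2 of the 2 values shown sit). Compound 3, `CO/N=C\c1ccc(-c2nn(Cc3ccccc3)c3ccccc23)cc1`, differs from compound 2 in one place: a group of 4 heavy atoms (2 carbon, 1 nitrogen, 1 oxygen; no ring) in place of a group of 3 heavy atoms (1 carbon, 2 oxygen; no ring), on an aromatic carbon. Among the compounds with values here, no measured step exists for this change. Only limits are known, so no step beyond the scatter can be expected either way; the estimated step that the limit leaves unreadable from compound 2 to compound 3 is close to none. Compound 3 is expected at about 12000 nM, with a range from 2000 nM to 60000 nM.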

Compound 3, half-maximal inhibitory concentration: > 10000 nM
Compound 3 was reported as a limit (the forecaster's own chance of this, stated with the estimate: 70%); the middle value lies beyond the limit too.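

Compound 2 and compound 3 are both limits, so the step between them cannot be read: the limit of > 10000 nM in this assay, at which 3 of the 3 values shown sit.

The compounds shown leave open which change, if any, to the shared core would give a value inside the readable range.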